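Removing a Protecting Group from an Amide Nitrogen

This account rests on a few compounds, and the source may have more. Where it says the series, first, only, none or still open, it means among the compounds named here.

Compound 1 `O=C(c1ccc(Cn2c(=O)c3ccccc3[s+]2[O-])cc1)N1CCCCC1` and compound 2 `CC(C)(C)OC(=O)N(Cc1ccco1)C(=O)c1ccc(Cn2c(=O)c3ccccc3[s+]2[O-])cc1` share the same core. In an ADME assay on RAW264.7 cells (Mus musculus) for cytotoxicity, read by WST assay (on this read-out lower numbers stand for higher toxicity in this test and higher numbers for lower toxicity in this test), compound 2 gives 87300 nM. Compound 1 gives > 100000 nM in this assay, which is a limit of the test rather than a number. Compound 2 is thus the only number shown, standing beside one limit (the limit of > 100000 nM in this assay, at which 1 of the 2 values shown sits). Going by these compounds, compound 3 `O=C(NCc1ccco1)c1ccc(Cn2c(=O)c3ccccc3[s+]2[O-])cc1` is untested; it differs from compound 2 by hydrogen in place of tert-butoxycarbonyl on an amide-type nitrogen. Among the compounds with values here, no measured step exists for guidance, so the expected step is small, toward lower toxicity and within the scatter, a 1.1-fold higher number from compound 2 to compound 3 (0.06 log units; within the scatter). Compound 3 is estimated at 100000 nM in this assay, between 50000 nM and 200000 nM.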

Compound 3, concentration lethal to 50% of the cells: > 100000 nM
Compound 3: only a limit was reported (the forecaster's own chance of this, stated with the estimate: 55%); the middle value lies on the limit itself.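

In this assay, hydrogen in place of tert-butoxycarbonyl on the amide-type nitrogen gives an at least 1.1-fold higher number from compound 2 to compound 3 (0.05 log units; that floor lies within the scatter), so removing this group brings no rise in toxicity in this test. Going by these compounds, the true size of that step stays unknown because the read-out ends at a limit: the limit of > 100000 nM in this assay, at which 2 of the 3 values shown sit. The step between compound 1 and compound 3 cannot be read, since both values are limits.

Still open, on these data alone, is how a methyl or acetyl group on this nitrogen would read, and whether an amine or a carboxylic acid in place of the (furan-2-yl)methyl group would give a number rather than a limit.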